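Aryl variation on a pyrazolopyridine ketone series

This account rests on a few compounds, and the source may have more. Where it says the series, first, only, none or still open, it means among the compounds named here.

Measured so far:
Compound 1 `CCCS(=O)(=O)Nc1ccc(F)c(C(=O)c2n[nH]c3ncc(-c4ccc(O)cc4)cc23)c1F`: 0.75%
Compound 2 `CCCS(=O)(=O)Nc1ccc(F)c(C(=O)c2n[nH]c3ncc(-c4ccccc4N)cc23)c1F`: 23%
Compound 3 `CCCS(=O)(=O)Nc1ccc(F)c(C(=O)c2n[nH]c3ncc(-c4ccc(OC)cc4Cl)cc23)c1F`: 5.3%

In an assay for binding affinity to dual specificity mitogen-activated protein kinase kinase 4 (Homo sapiens), read by KINOMEscan, tested at 100 nM (a higher number here means a weaker effect of the compound at the concentration tested, a lower number a stronger effect), compound 3 gives 5.3%, the second highest of the three numbers. Its nearest neighbour is compound 1, with a number 4.6 percentage points higher from compound 1 to compound 3 (within the scatter); its furthest is compound 2, with a number 17.7 percentage points lower from compound 2 to compound 3 (beyond the scatter). Compound 4 `CCCS(=O)(=O)Nc1ccc(F)c(C(=O)c2n[nH]c3ncc(-c4ccc(NS(C)(=O)=O)cc4)cc23)c1F` carries the change (4-(methanesulfonamido)phenyl in place of 2-chloro-4-methoxyphenyl on an aromatic carbon). Among the measured compounds shown here, no measured step touches a methanesulfonamido group, so only indirect guidance exists: compound 1, which also carries a hydrogen-bond donor on the 4-position of the pendant phenyl, gives 0.75%, and compound 2, the sole clear outlier, carries its donor at the 2-position. Compound 4 is therefore expected to land near compound 1 and compound 3, as a number 3.3 percentage points lower from compound 3 to compound 4 (within the scatter). The estimate for compound 4 is 2%, within 0.3% to 15%.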

Compound 4, a percentage reported as activity, at one concentration (the size of the read-out at that concentration, not a potency): 0.85%
Compound 4: middle estimate off by 1.2 percentage points, on the high side; measured number inside the range.
By their numbers in this assay, from the lowest: compounds 1, 4 and 3 (each within the scatter of the next); then compound 2.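

In this assay, among the compounds shown here, methanesulfonamido in place of hydroxy on the phenyl gives a number 0.1 percentage points higher from compound 1 to compound 4 (within the scatter), so compound 1 and compound 4 cannot be told apart despite the change of group. 4-(Methanesulfonamido)phenyl in place of 2-chloro-4-methoxyphenyl gives a number 4.5 percentage points lower from compound 3 to compound 4 (within the scatter), while in place of 2-aminophenyl it gives a number 22.2 percentage points lower from compound 2 to compound 4 (beyond the scatter), leaving compound 2 as the only member set apart. No available data explain these readings.

Still open, on these data alone, is whether 4-aminophenyl would read with compound 1 or with compound 2. A carboxylic acid on the phenyl also remains untested in the compounds shown.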